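The compounds below may be only part of what the source reports. "The series", "measured", "known", "first", "only" and "open" are said of these compounds alone.

Values measured in an ADME assay on microsomes from liver (Rattus norvegicus) for metabolic stability, using NADPH, with a stated time of 10 min; on this read-out lower numbers stand for a less stable compound and higher numbers for a more stable compound:
- compound 1 `NCCCCN(C[C@@H]1Cc2cccnc2CN1)[C@H]1CCCc2cccnc21` gives 37%
- compound 2 `NCCCCN(C[C@H]1Cc2nccnc2CN1)[C@H]1CCCc2cccnc21` gives 50%
- compound 3 `NC/C=C\CN(C[C@H]1Cc2ncccc2CN1)[C@H]1CCCc2cccnc21` gives 11%

Of these three, compound 3 has the lowest number (11%), and its gaps to the other two lie beyond the usual scatter of repeated measurements. Compound 1 is the nearer of the two, and compound 2 is the further. Going by the values given here, these compounds differ from one another in more than one place, so no measured pair isolates a single structural change.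

The next compound to be tested is compound 4 `NC(=O)NC/C=C\CN(C[C@H]1Cc2ncccc2CN1)[C@H]1CCCc2cccnc21`, which has carbamoyl in place of hydrogen on an amine nitrogen whose other neighbour is a saturated chain carbon (carbamoyl in place of hydrogen on an amine nitrogen). The same difference can be read as amino to ureido.

Among the compounds with values here, with no measured step to serve as a guide, the expectation is necessarily loose. Compound 3 sits low, while compound 1 (37%) and compound 2 (50%) show that higher numbers occur among these close relatives. A moderate rise beyond the scatter is therefore expected, although a change too small to distinguish from the scatter cannot be ruled out. The expected size of the step of a number 19 percentage points higher from compound 3 to compound 4 (beyond the scatter) is only an estimate. In this assay compound 4 is estimated at 30%, with an expected range from 12% to 55% for repeated measurements.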

Compound 4, percent of the compound remaining: 1%
For compound 4 the middle estimate is 29 percentage points above the measured one, and the stated range ends above it.
By their numbers in this assay, from the lowest: compounds 4 and 3 (each within the scatter of the next); then compound 1; then compound 2.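

In this assay, putting carbamoyl in place of hydrogen on the amine nitrogen gives a number 10 percentage points lower from compound 3 to compound 4 (within the scatter). Going by these compounds alone, this is the first measured step in the set that changes only one place, and it shows that turning the amino end of the chain into a ureido end does not separate the two compounds on this read-out: the rise that seemed possible did not appear, and a real fall cannot be claimed either. With compound 3 at 11%, the read-out also leaves little room for any further fall to show, and nothing available here explains the result for either compound.

Still open, on these data alone, is whether a different group on this same nitrogen, such as acetyl or methyl, or a carboxylic acid in place of the amine at the chain end, would move the number beyond the scatter. As far as these compounds go, it is also open whether carbamoyl would give a similar step on the saturated chain of compound 1, where the starting number of 37% leaves more room for a change to be seen.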